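The source may report more compounds than this note shows. Statements on the series, on what has been measured and on what is new or still open speak of the compounds shown alone.

In an assay on isolated protein for inhibition of Fatty-acid amide hydrolase 1 (Homo sapiens), with a stated time of 60 min (a higher number here means a weaker inhibitor, a lower number a stronger inhibitor), compound 1 `O=C(Nc1cccc2cn[nH]c12)N1CCN(Cc2cccc(Oc3ccc(Cl)cc3)c2)CC1` gives 1300 nM; compound 2 `Cc1nc2cc(NC(=O)N3CCN(Cc4cccc(Oc5ccc(Cl)cc5)c4)CC3)ccc2o1` gives 7.7 nM; compound 3 `O=C(Nc1noc2cccnc12)N1CCN(Cc2cccc(Oc3ccc(Cl)cc3)c2)CC1` gives 13 nM.

Compound 1 stands highest of these three numbers, so it is the weakest inhibitor shown: compound 3 is nearest to it and compound 2 furthest. Compound 4 `O=C(Nc1cn2ccccc2n1)N1CCN(Cc2cccc(Oc3ccc(Cl)cc3)c2)CC1` keeps the shared core and differs from compound 1 only at the amide-type nitrogen: a group of 9 heavy atoms (7 carbon, 2 nitrogen; one five-membered aromatic ring with 2 hetero atoms, one six-membered aromatic ring with 1 hetero atom) in place of a group of 9 heavy atoms (7 carbon, 2 nitrogen; one five-membered aromatic ring with 2 hetero atoms, one six-membered aromatic ring of carbon only), on an amide-type nitrogen. Within the data shown here, two measured steps bear on this. Both a 170-fold lower number from compound 1 to compound 2 (2.23 log units; beyond the scatter) and a 100-fold lower number from compound 1 to compound 3 (2.00 log units; beyond the scatter) replaced the same indazolyl group with an aromatic bicycle lacking a hydrogen-bond donor, and both gave large drops. The group entering compound 4 likewise carries no donor, so a drop of similar size is expected: a 65-fold lower number from compound 1 to compound 4 (1.81 log units; beyond the scatter). Compound 4 is therefore estimated at 20 nM, with a range from 5 nM to 150 nM.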

Compound 4, half-maximal inhibitory concentration: > 10000 nM
Compound 4: a limit, no number; the forecaster's own chance of this, stated with the estimate: 0%; middle value at least 500-fold (2.69 log units) from the limit.
By their numbers in this assay, from the lowest: compounds 2 and 3 (each within the scatter of the next); then compound 1. At a limit, above all of these: compound 4.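

In this assay compound 4 gives a limit, not a number: the limit of > 10000 nM in this assay, at which 1 of the 4 values shown sits.

At this amide-type nitrogen, then, a group with 0 hydrogen-bond donors does not by itself give a stronger inhibitor, since the number rises with an at least 7.6-fold higher number from compound 1 to compound 4 (0.88 log units; beyond the scatter). The ring count alone does not settle it either: the groups of compounds 3 and 4 have the same ring types, yet the change is an at least 760-fold higher number from compound 3 to compound 4 (2.88 log units; beyond the scatter), and the gap is similar with an at least 1200-fold higher number from compound 2 to compound 4 (3.11 log units; beyond the scatter).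

Going by these compounds, how far the true value of compound 4 lies past its limit remains open. So does whether a plain phenyl or a pyridinyl group at this nitrogen would behave more like compound 2 or compound 4.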